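The compounds below may be only part of what the source reports. "The series", "measured", "known", "first", "only" and "open" are said of these compounds alone.

In a functional assay on MCF7 cells (Homo sapiens) for cytotoxicity, read by MTT assay, with a stated time of 72 h, tested at 3 uM (a higher number here means more inhibition of growth at the concentration tested, a lower number less inhibition of growth), compound 1 `N/C(=N\NC(=S)N1CCCCCC1)c1ccccn1` gives 56% and stands highest of the three measured compounds; its differences to the other two lie beyond the scatter. Compound 2 `N/C(=N\NC(=S)N1CCOCC1)c1ccccn1` gives 44.5% in this assay, and compound 3 `N/C(=N\NC(=S)N1CCOCC1)c1ccc(F)cn1` gives 33.9% in this assay. How the cores of compound 1 and compound 2 differ is not broken down here.

Compound 2 and compound 3 differ in one place: fluoro in place of hydrogen on an aromatic carbon. This change produced a number 10.6 percentage points lower from compound 2 to compound 3 (beyond the scatter), a drop that lies beyond the scatter but remains modest in size.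

Compound 4 `N/C(=N\NC(=S)N1CCCCCC1)c1ccc(F)cn1` has not yet been tested in this assay. It differs from compound 1 in the same way that compound 3 differs from compound 2: fluoro in place of hydrogen on an aromatic carbon. Among the compounds with values here, the change is the same in each pair, down to its place on the ring, which is the whole basis for what can be expected; only one such step is known, and nothing else in the data bears on it.

Resting on the step seen from compound 2 to compound 3, compound 4 is expected to lie somewhat below compound 1 in this assay, the expected step being a number 11 percentage points lower from compound 1 to compound 4 (beyond the scatter). Compound 4 is therefore estimated to give about 45% in this assay, with the expected range running from 35% to 55%.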

Compound 4, percent growth inhibition at one concentration: 24.3%
Beside the measured number, compound 4's estimate is 20.7 percentage points above it; the measured number lies below the stated range.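

In this assay, fluoro in place of hydrogen on an aromatic carbon again lowers the number on the core of compound 1, the new step being a number 31.7 percentage points lower from compound 1 to compound 4 (beyond the scatter), and this step is large. Within the data shown here, the direction of the change therefore carries over from one core to the other in these two pairs, but its size does not, so the step seen on one core cannot simply be transferred to the other: the same change on two cores in this assay, a number 10.6 percentage points lower (beyond the scatter) from compound 2 to compound 3 and a number 31.7 percentage points lower (beyond the scatter) from compound 1 to compound 4, 21.1 percentage points apart, beyond the scatter of two such steps This does not show why the size of the step depends on the core, and with only two pairs it gives no general rule for what the same change would do on any further core.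

The compounds shown leave open whether a chloro or a methyl group in that same place, two atoms from the ring nitrogen, would also lower the number, and whether its step would likewise differ between the two cores. They also leave open how a methoxy group or an amine in that place would behave, and so whether the difference between the two steps belongs to fluoro alone or extends to other groups.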